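A few compounds are considered here, and "the series" means these few. Any claim that something is new, unique, unknown or untested is made for them only; others in the source may bear on it.

Of the compounds shown here, two have been measured in a functional assay on Ehrlich cells (Mus musculus) for cytotoxicity, read by trypan blue exclusion, with a stated time of 48 h; on this read-out higher numbers stand for weaker inhibition and lower numbers for stronger inhibition. Compound 1 `COc1ccc(-c2csc(NC(=O)COc3ccc(C(=O)c4ccccc4)cc3C)n2)cc1` gives 27100 nM there, and compound 2 `Cc1cc(C(=O)c2ccc(F)cc2)ccc1OCC(=O)Nc1nc(-c2ccccc2)cs1` gives 35200 nM. Of these two numbers compound 2 has the higher one, but the gap to compound 1 lies within the scatter of repeated measurements, so the two compounds cannot be told apart on this read-out. Compound 3 `COc1ccc(-c2csc(NC(=O)COc3ccc(C(=O)c4ccc(F)cc4)cc3C)n2)cc1` has not yet been measured. It differs from compound 2 in one place: methoxy in place of hydrogen on an aromatic carbon. Among the measured compounds shown here, no pair of measured compounds shows this change on its own; compound 1 carries the methoxy group without the fluorine that compound 2 and compound 3 carry, and its value sits within the scatter of compound 2. The expected step is a 1.2-fold lower number from compound 2 to compound 3 (0.07 log units; within the scatter), with no direction beyond the scatter. Compound 3 is expected to give about 30000 nM in this assay, within a range from 12000 nM to 75000 nM.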

Compound 3, half-maximal inhibitory concentration: 5200 nM
For compound 3 the middle estimate is 5.8-fold (0.76 log units) above the measured one, and the stated range ends above it.
By their numbers in this assay, from the lowest: compound 3; then compounds 1 and 2 (each within the scatter of the next).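

In this assay, methoxy in place of hydrogen on an aromatic carbon, para to a large group, brings a 6.8-fold lower number from compound 2 to compound 3 (0.83 log units; beyond the scatter), so this position does respond to the change when the fluorine is present. Fluoro in place of hydrogen, with the methoxy group already there, brings a 5.2-fold lower number from compound 1 to compound 3 (0.72 log units; beyond the scatter), so the lowest number among these compounds belongs to the one that carries both groups. Nothing measured here accounts for either step.

On these data alone, each change is seen in a single pair and only with the other group in place, so it remains open whether methoxy would bring a step of this size on a compound without the fluorine. Also open, as far as these compounds go, is whether another group at this position, such as an amine or a hydroxyl, would shift the number in the same way.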